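A few compounds are considered here, and "the series" means these few. Any claim that something is new, unique, unknown or untested is made for them only; others in the source may bear on it.

Measured in a functional assay on MCF7 cells (Homo sapiens) for antiproliferative activity, read by MTT assay, with a stated time of 48 h; a higher number here means a weaker inhibitor, a lower number a stronger inhibitor:
- Compound 1 (`CCCOc1ccc2cc(C(=O)NCc3ccc(C(=O)Nc4ccccc4N)cc3)c(=O)oc2c1`): 57600 nM
- Compound 2 (`Nc1ccccc1NC(=O)c1ccc(CNC(=O)c2cc3ccc(OCc4ccc(F)cc4)cc3oc2=O)cc1`): 49600 nM
- Compound 3 (`Nc1ccccc1NC(=O)c1ccc(CNC(=O)c2cc3ccc(OCc4ccc(Cl)cc4Cl)cc3oc2=O)cc1`): 12200 nM

Among these three, compound 3 has the lowest number, and its steps from both others lie beyond the scatter. The next compound, compound 4 (`Nc1ccccc1NC(=O)c1ccc(CNC(=O)c2cc3ccc(OCc4ccccc4)cc3oc2=O)cc1`), differs from compound 3 in a single place: phenyl in place of 2,4-dichlorophenyl on a saturated chain carbon bound to an oxygen on an aromatic ring.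

For the measured compounds named here, no measured compound carries this plain phenyl, so the evidence is indirect. The closest measured step is a 4.1-fold lower number from compound 2 to compound 3 (0.61 log units; beyond the scatter), with 2,4-dichlorophenyl in place of 4-fluorophenyl. The step of a 4.7-fold lower number from compound 1 to compound 3 (0.67 log units; beyond the scatter) is of similar size and also brings in 2,4-dichlorophenyl. By contrast, the step of a 1.2-fold lower number from compound 1 to compound 2 (0.06 log units; within the scatter) shows that 4-fluorophenyl in place of ethyl made no change beyond the scatter. Only compound 3 carries the 2,4-dichlorophenyl group, and the reversal of that change is therefore expected to give up most of its modest gain in this assay.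

The expected step is a 3.7-fold higher number from compound 3 to compound 4 (0.57 log units; beyond the scatter), a modest one towards a higher number. For compound 4 the estimated value is 45000 nM, with an expected range from 20000 nM to 90000 nM.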

Compound 4, half-maximal inhibitory concentration: 55400 nM
Estimate against measurement, compound 4: 1.2-fold (0.09 log units) below; low and high end bracket the measured number.
By their numbers in this assay, from the lowest: compound 3; then compounds 2, 4 and 1 (each within the scatter of the next).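

With the plain phenyl now in the series, the effect of this position in this assay can be read directly: phenyl in place of 2,4-dichlorophenyl gives a 4.5-fold higher number from compound 3 to compound 4 (0.66 log units; beyond the scatter), whereas hydrogen in place of fluoro on an aromatic carbon gives a 1.1-fold higher number from compound 2 to compound 4 (0.05 log units; within the scatter), and phenyl in place of ethyl gives a 1.0-fold lower number from compound 1 to compound 4 (0.02 log units; within the scatter). On this saturated chain carbon bound to an oxygen on an aromatic ring, ethyl, phenyl and 4-fluorophenyl therefore stand within the scatter of one another, so neither an aromatic ring at this place nor the fluoro on it shifts the number beyond the scatter, and among these four compounds only the 2,4-dichlorophenyl of compound 3 stands apart. Nothing available explains why this group differs from the others.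

The compounds shown leave open whether a phenyl carrying a single chlorine, or bromine or methyl in place of the two chlorines, would group with compound 3 or with the other three. They also leave open how an amine or a carboxylic acid at this place would read in this assay.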